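A step from compound 3 to compound 4

The source may report more compounds than this note shows. Statements on the series, on what has been measured and on what is new or still open speak of the compounds shown alone.

Measured in an ADME assay on Vero cells (Chlorocebus sabaeus) for cytotoxicity, read by MTT assay, with a stated time of 48 h (on this read-out lower numbers stand for stronger inhibition and higher numbers for weaker inhibition), each value being a limit and not a number:
compound 1 `Cc1cccc(C(=O)OC2CCC(CN3CCN(c4cc(=O)c5cc(C(F)(F)F)cc([N+](=O)[O-])c5s4)CC3)CC2)c1`: > 64 ug/mL
compound 2 `CS(=O)(=O)OC1CCC(CN2CCN(c3cc(=O)c4cc(C(F)(F)F)cc([N+](=O)[O-])c4s3)CC2)CC1`: > 64 ug/mL
compound 3 `CC(C)S(=O)(=O)OC1CCC(CN2CCN(c3cc(=O)c4cc(C(F)(F)F)cc([N+](=O)[O-])c4s3)CC2)CC1`: > 64 ug/mL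

Compound 3 has only the limit > 64 ug/mL. It shares this position with the other two compounds: the limit of > 64 ug/mL in this assay, at which 3 of the 3 values shown sit.

Compound 4 `O=c1cc(N2CCN(CC3CCC(NS(=O)(=O)c4ccccc4)CC3)CC2)sc2c([N+](=O)[O-])cc(C(F)(F)F)cc12` has (phenylsulfonyl)amino in place of (isopropylsulfonyl)oxy on a saturated ring carbon.

Going by the values given here, three measured steps bear on this change, though none gives a size. There is a step that the two limits leave unreadable from compound 1 to compound 3, a step that the two limits leave unreadable from compound 2 to compound 3 and a step that the two limits leave unreadable from compound 1 to compound 2. From the compounds shown here alone, none of them places (phenylsulfonyl)amino on the ring carbon, so the change itself remains untested.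

The expectation therefore rests on the limit shared by compound 1, compound 2 and compound 3, with no direction favoured. In this assay, the expected outcome is a number no higher from compound 3 to compound 4 (the limit leaves the size open), with nothing beyond the scatter anticipated. For compound 4 the estimated value is 64 ug/mL, with an expected range from 32 ug/mL to 128 ug/mL.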

Compound 4, half-maximal inhibitory concentration: > 64 ug/mL
Compound 4: no number, only a limit; the forecaster's own chance of this, stated with the estimate: 85%; the middle value lies on the limit itself.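

In this assay compound 4 gives > 64 ug/mL, which is a limit and not a number. Its steps to compound 1, compound 2 and compound 3 cannot be read, because all four compounds share one position: the limit of > 64 ug/mL in this assay, at which 4 of the 4 values shown sit. The compounds shown leave open whether the changes among them alter the read-out at all.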